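Chloro in place of hydrogen at the assay limit

The source may hold more compounds than are shown below. What is called first, only, known or untested is meant among the compounds shown, and "the series" means these compounds.

In an ADME assay on microsomes from liver (Homo sapiens) for metabolic stability, read by LC-MS, with NADPH named in the record, with a stated time of 60 min, tested at 1 uM, in the absence of a further agent (a lower number here means that less of the compound is left, a higher number that more of the compound is left), compound 1 `COc1ccc(-c2c(C)nc3c(N4CC[C@@H](NC(=O)Nc5ccccc5)C4)cc(C)nn23)cc1OC` gives > 95% as a limit. Compound 2 `COc1ccc(-c2c(C)nc3c(N4CC[C@@H](NC(=O)Oc5cccc(C)c5)C4)cc(C)nn23)cc1OC` gives > 95% as a limit too. Compound 3 `COc1ccc(-c2c(C)nc3c(N4CC[C@@H](NS(=O)(=O)c5ccccc5)C4)cc(C)nn23)cc1OC` also gives > 95% as a limit. All three share the limit of > 95% in this assay, at which 3 of the 3 values shown sit, without any number to rank them. Compound 4 `COc1ccc(-c2c(C)nc3c(N4CC[C@@H](NS(=O)(=O)c5ccc(Cl)cc5)C4)cc(C)nn23)cc1OC` differs from compound 3 by chloro in place of hydrogen on an aromatic carbon and so carries chloro in place of hydrogen on an aromatic carbon. The measured changes ending at compound 3 are a step that the two limits leave unreadable from compound 1 to compound 3 and a step that the two limits leave unreadable from compound 2 to compound 3 and neither offers a size to carry over. No step beyond the usual scatter is therefore expected in this assay for this change. The expected step is a number at least 1 percentage points lower from compound 3 to compound 4 (that floor lies within the scatter) and no more. Compound 4 is expected to read 94% with 82% to 100% as its estimated range.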

Compound 4, percent of the compound remaining: > 95%
Compound 4 gave a limit, no number; the forecaster's own chance of this, stated with the estimate: 55%; middle value at least 1 percentage points away from the limit.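

No step from compound 1, compound 2 or compound 3 to compound 4 can be read: the limit of > 95% in this assay, at which 4 of the 4 values shown sit.

The compounds shown leave open how far any of them differs from the others in this assay, including whether chloro in place of hydrogen matters there.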